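Bromophenyl in Place of Dimethoxyphenyl on the Cinnamate Ester

This account rests on a few compounds, and the source may have more. Where it says the series, first, only, none or still open, it means among the compounds named here.

Compound 2 `COc1cc(OC)c(OC)cc1/C=C/COC(=O)/C=C/c1ccc(OC)c(OC)c1` has the lowest number of the three measured in a functional assay on the whole organism (strain Kunming) with Mus musculus as the target, with a stated time of 0.5 h, at a dose of 300 mg/kg by the intraperitoneal route (a higher number here means a weaker effect of the compound at the dose given, a lower number a stronger effect), giving 0%. Compound 1 `COc1ccccc1/C=C/C(=O)OC/C=C/c1cc(OC)c(OC)cc1OC` gives 50%, and compound 3 `COc1cc(OC)c(OC)cc1/C=C/COC(=O)/C=C/c1c(OC)ccc(OC)c1OC` gives 50%. Among the compounds with values here, the single measured step that bears on the new change is a number 50 percentage points lower from compound 1 to compound 2 (beyond the scatter), which shows that the aryl group on this chain carbon can shift the read-out widely. Compound 4 `COc1cc(OC)c(OC)cc1/C=C/COC(=O)/C=C/c1ccc(Br)cc1` differs from compound 2 by 4-bromophenyl in place of 3,4-dimethoxyphenyl on a double-bonded chain carbon bound to a double-bonded chain carbon. Within the data shown here, no measured step involves 4-bromophenyl, so the direction rests only on the observation that both other aryl groups stand well above compound 2. Compound 4 is therefore expected to rise, a number 40 percentage points higher from compound 2 to compound 4 (beyond the scatter), with an estimate of 40% and a range from 0% to 70%.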

Compound 4, a percentage reported as activity, at one dose (the size of the read-out at that dose, not a potency): 25%
Compound 4: the middle estimate sits 15 percentage points above what was measured, and the stated range covers the measured number.
By their numbers in this assay, from the lowest: compound 2; then compound 4; then compounds 1 and 3 (each within the scatter of the next).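

In this assay, replacing either methoxy-bearing aryl group with 4-bromophenyl gives an intermediate result: a number 25 percentage points higher from compound 2 to compound 4 (beyond the scatter) and a number 25 percentage points lower from compound 1 to compound 4 (beyond the scatter). This position on the double-bonded chain carbon therefore tolerates a ring without oxygen while still separating it from 3,4-dimethoxyphenyl, which keeps the lowest number of the four compounds. No evidence on hand accounts for these differences. The compounds shown leave open whether the bromine or the loss of the two methoxy groups sets this level. A plain phenyl or 4-chlorophenyl could separate those two, and how a ring bearing an amine or a carboxylic acid would read remains an open question.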